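Urea in place of amide on the shared core

The source may hold more compounds than are shown below. What is called first, only, known or untested is meant among the compounds shown, and "the series" means these compounds.

Compound 2 `COc1cc(-c2nn(-c3cccc(NC(=O)c4cccc(C(F)(F)F)c4)c3)cc2-c2ccncc2)ccc1Cl` carries an amide link to a 3-(trifluoromethyl)phenyl. In a functional assay on UACC-62 cells (Homo sapiens) for inhibition, read by sulforhodamine B assay, with a stated time of 48 h (a lower number here means that less compound is tolerated, a higher number that more compound is tolerated), compound 2 gives only a limit, > 50000 nM. For the measured compounds named here, of the three values measured so far, one sits at that limit (the limit of > 50000 nM in this assay, at which 1 of the 3 values shown sits), the other two are numbers. Compound 1 `O=C(Nc1cccc(-n2cc(-c3ccncc3)c(-c3ccc(Cl)c(O)c3)n2)c1)Nc1cccc(C(F)(F)F)c1` gives 21900 nM in this assay, and compound 3 `O=C(Nc1cccc(-n2cc(-c3ccncc3)c(-c3ccc(Cl)c(O)c3)n2)c1)Nc1cc(C(F)(F)F)cc(C(F)(F)F)c1` gives 8460 nM in this assay. Going by the values given here, the single measured step between them, a 2.6-fold lower number from compound 1 to compound 3 (0.41 log units; beyond the scatter), shows that a second trifluoromethyl on the urea-bound phenyl moves the number within the same urea series.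

Compound 4 `COc1cc(-c2nn(-c3cccc(NC(=O)Nc4ccc(Cl)c(C(F)(F)F)c4)c3)cc2-c2ccncc2)ccc1Cl` differs from compound 2 by (4-chloro-3-(trifluoromethyl)phenyl)amino in place of 3-(trifluoromethyl)phenyl on a carbonyl carbon; the amide of compound 2 becomes a urea, and the urea-bound phenyl now carries both a chlorine and a trifluoromethyl. Among the compounds with values here, no measured step reproduces this exact change, and no measured pair isolates the methoxy-bearing ring that compound 2 and compound 4 share. The nearest evidence is that both urea compounds, compound 1 with 21900 nM and compound 3 with 8460 nM, give numbers rather than a limit, while the amide compound 2 does not.

Compound 4 is therefore expected to return a number in this assay, in the region of the two ureas, estimated at 20000 nM with a range of 6000 nM to 50000 nM. The step of an at least 2.5-fold lower number from compound 2 to compound 4 (0.39 log units; beyond the scatter) is thus expected to be a move from a limit into measurable territory, with a real chance that only a limit is reported again.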

Compound 4, concentration lethal to 50% of the cells: 11600 nM
Compound 4: middle estimate off by 1.7-fold (0.24 log units), on the high side; the measured number falls inside the stated range.
By their numbers in this assay, from the lowest: compounds 3, 4 and 1 (each within the scatter of the next, the first and the last beyond it). At a limit, above all of these: compound 2.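

Working note on the carbonyl carbon whose other neighbour is an amide-type nitrogen: in this assay, (4-chloro-3-(trifluoromethyl)phenyl)amino in place of 3-(trifluoromethyl)phenyl gives an at least 4.3-fold lower number from compound 2 to compound 4 (0.63 log units; beyond the scatter). For the compounds shown here, this is the first single-place comparison between an amide and a urea, and it shows that, on the methoxy-bearing core shared by this pair, the change takes the read-out from a limit to a number. Compound 2 remains a limit, not a number, so the true size of this step stays unknown: the limit of > 50000 nM in this assay, at which 1 of the 4 values shown sits.

The entering group brings the amino link and the chlorine together, so the compounds shown do not separate what each contributes to the step, and they give no single-place comparison between the methoxy-bearing core and the hydroxy-bearing core of the other ureas. Also open is how the number would respond to a carboxylic acid or a dimethylamino group in place of the chlorine on the urea-bound phenyl, since every substituent on that ring shown so far is a halogen or a trifluoromethyl.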